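The compounds below may be only part of what the source reports. "The series", "measured", "known", "first", "only" and "open" are said of these compounds alone.

In a functional assay on HepG2 cells (Homo sapiens) for inhibition, read by MTT assay, with a stated time of 48 h (on this read-out higher numbers stand for weaker inhibition and lower numbers for stronger inhibition), three compounds sharing one core have been measured. Compound 1 `COc1ccc(-n2c(SC)nnc2-c2cc(OC)c(OC)c(OC)c2)cc1` gives > 60000 nM, which is a limit of the assay and not a number. Compound 2 `COc1ccc(-n2c(SCC(=O)c3ccccc3)nnc2-c2cc(OC)c(OC)c(OC)c2)cc1` gives 16200 nM. Compound 3 `COc1ccc(-n2c(SCC(=O)c3ccc4ccccc4c3)nnc2-c2cc(OC)c(OC)c(OC)c2)cc1` gives > 60000 nM, again a limit and not a number. Compound 3 therefore stands at the limit of > 60000 nM in this assay, at which 2 of the 3 values shown sit.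

Compound 4 `COc1ccc(-n2c(SCC(=O)C3CC3)nnc2-c2cc(OC)c(OC)c(OC)c2)cc1` carries cyclopropyl in place of naphthalen-2-yl on a carbonyl carbon, and the difference is cyclopropyl in place of naphthalen-2-yl on a carbonyl carbon. For the measured compounds named here, two measured steps bear on this change. Placing benzoyl on the saturated chain carbon bound to sulfur gave an at least 3.7-fold lower number from compound 1 to compound 2 (0.56 log units; beyond the scatter), while naphthalen-2-yl in place of phenyl on the carbonyl carbon gave an at least 3.7-fold higher number from compound 2 to compound 3 (0.56 log units; beyond the scatter). Compound 4 keeps the carbonyl but loses naphthalen-2-yl, so a modest move towards stronger inhibition is expected, although it may not leave the limit. The expected change is an at least 2.0-fold lower number from compound 3 to compound 4 (0.30 log units; that floor lies within the scatter). Compound 4 is estimated at 30000 nM, within an expected range of 12000 nM to 60000 nM.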

Compound 4, half-maximal inhibitory concentration: > 60000 nM
Compound 4: a limit, no number; the forecaster's own chance of this, stated with the estimate: 40%; at least 2.0-fold (0.30 log units) between middle value and limit.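

Cyclopropyl in place of phenyl on the carbonyl carbon gives an at least 3.7-fold higher number from compound 2 to compound 4 (0.56 log units; beyond the scatter) in this assay, so at this position both cyclopropyl and naphthalen-2-yl stand apart from the phenyl of compound 2. Keeping the carbonyl on the saturated chain carbon is thus not enough on its own: compound 4 carries it, and its result is a limit of the assay and not a number. The steps from compound 3 to compound 4 and from compound 1 to compound 4 cannot be read, since both ends of each are limits, and compound 2 alone has left the following: the limit of > 60000 nM in this assay, at which 3 of the 4 values shown sit.

On these data alone, it remains open whether a chlorophenyl or a pyridine ring on the carbonyl carbon would keep or extend the value of compound 2. As far as these compounds go, how far compound 1, compound 3 and compound 4 differ from one another also stays unknown.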